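This account rests on a few compounds, and the source may have more. Where it says the series, first, only, none or still open, it means among the compounds named here.

Three measured compounds share one core and differ only in the aromatic group attached to the carbon that carries a double bond to nitrogen. Compound 1 `COc1ccc(/C=N/NC(=O)Nc2ccc(Oc3ccnc(-c4nncn4CCN(C)C)c3)c(F)c2)c(OC)c1OC` bears a 2,3,4-trimethoxyphenyl group there, compound 2 `COc1cc(/C=N/NC(=O)Nc2ccc(Oc3ccnc(-c4nncn4CCN(C)C)c3)c(F)c2)cc(OC)c1OC` a 3,4,5-trimethoxyphenyl group, and compound 3 `CN(C)CCn1cnnc1-c1cc(Oc2ccc(NC(=O)N/N=C/c3ccc(F)cc3Cl)cc2F)ccn1` a 2-chloro-4-fluorophenyl group. In a functional assay on NCI-H460 cells (Homo sapiens) for cytotoxicity, read by MTT assay, with a stated time of 72 h (on this read-out higher numbers stand for weaker inhibition and lower numbers for stronger inhibition), compound 1 gives 1790 nM, compound 2 gives 2770 nM and compound 3 gives 720 nM. Compound 2 thus holds the highest of the three numbers; its nearest neighbour is compound 1, with a 1.5-fold higher number from compound 1 to compound 2 (0.19 log units; within the scatter), and its furthest is compound 3, with a 3.8-fold lower number from compound 2 to compound 3 (0.59 log units; beyond the scatter).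

Compound 4 `Cc1cc(/C=N/NC(=O)Nc2ccc(Oc3ccnc(-c4nncn4CCN(C)C)c3)c(F)c2)cc(C)c1O` has not yet been measured. Its change from compound 2 is 4-hydroxy-3,5-dimethylphenyl in place of 3,4,5-trimethoxyphenyl on a carbon with a double bond to nitrogen. Among the measured compounds shown here, no measured step exchanges methoxy groups for a hydroxyl and methyl groups, so the known steps bear on it only indirectly: a 1.5-fold higher number from compound 1 to compound 2 (0.19 log units; within the scatter) shows that rearranging three methoxy groups changes little, while a 2.5-fold lower number from compound 1 to compound 3 (0.40 log units; beyond the scatter) and a 3.8-fold lower number from compound 2 to compound 3 (0.59 log units; beyond the scatter) show that a quite different aromatic group can lower the number modestly. In this assay the expected step is therefore small, a 1.4-fold lower number from compound 2 to compound 4 (0.14 log units; within the scatter), within the scatter. The estimate for compound 4 is 2000 nM, with a range from 600 nM to 6000 nM.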

Compound 4, half-maximal inhibitory concentration: 2010 nM
Beside the measured number, compound 4's estimate is 1.0-fold (0.00 log units) below it, and the stated range covers the measured number.
By their numbers in this assay, from the lowest: compound 3; then compounds 1, 4 and 2 (each within the scatter of the next).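

In this assay, the exchange on the carbon with a double bond to nitrogen is a large one, from 12 heavy atoms to 9 and from 0 hydrogen-bond donors to 1, yet it stays within the scatter: a 1.4-fold lower number from compound 2 to compound 4 (0.14 log units; within the scatter). The comparison with the other trimethoxy arrangement gives the same reading, a 1.1-fold higher number from compound 1 to compound 4 (0.05 log units; within the scatter), so a phenyl group carrying a hydroxyl and two methyl groups sits with the two trimethoxyphenyl compounds, and methoxy groups are not needed to stay in that range. The 2-chloro-4-fluorophenyl group remains apart, a 2.8-fold higher number from compound 3 to compound 4 (0.45 log units; beyond the scatter), and compound 3 now has steps beyond the scatter to all three other compounds.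

Nothing shown explains these numbers, and the single exchange cannot tell whether the hydroxyl and the methyl groups each leave the number unchanged or offset one another. An amine or a carboxylic acid at the same place on the phenyl ring, or a plain 4-hydroxyphenyl group without the methyl groups, would test how far this tolerance extends.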